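A few compounds are considered here, and "the series" means these few. Any claim that something is new, unique, unknown or untested is made for them only; others in the source may bear on it.

Measured compounds, in an ADME assay on GES1 cells (Homo sapiens) for inhibition, read by MTT assay, with a stated time of 72 h; a lower number here means a stronger inhibitor, a higher number a weaker inhibitor:
Compound 1 `CCCCCc1c(C)nc2nc(SCc3ccc(Cl)cc3)nn2c1Nc1cc(-c2ccccc2)[nH]n1` gives > 50000 nM, a limit of the assay.
Compound 2 `Cc1cc(Nc2cc(-c3cccs3)[nH]n2)n2nc(SCc3ccc(Br)cc3)nc2n1` gives 38700 nM.
Compound 3 `CCCSc1nc2nc(C)cc(Nc3cc(-c4ccccc4)[nH]n3)n2n1` gives > 50000 nM, a limit of the assay.

For the measured compounds named here, compound 2 holds the only number in the set; the other two values sit at the limit of > 50000 nM in this assay, at which 2 of the 3 values shown sit, so no ordering can be read. Compound 4 `Cc1cc(Nc2cc(C(C)(C)C)[nH]n2)n2nc(SCc3ccc(Br)cc3)nc2n1` differs from compound 2 by tert-butyl in place of thiophen-2-yl on an aromatic carbon. Going by the values given here, no step between measured compounds is available, so nothing here sizes this change in this assay. Given that compound 2 itself sits not far from the limit of > 50000 nM in this assay, at which 2 of the 3 values shown sit, the step is expected to be small, none beyond the usual scatter, and a limit rather than a number is a real possibility. Compound 4 is expected to give 45000 nM, within 20000 nM to 100000 nM. The step this estimate means is a 1.2-fold higher number from compound 2 to compound 4 (0.07 log units; within the scatter), expected to remain within the scatter.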

Compound 4, half-maximal inhibitory concentration: > 50000 nM
Compound 4 ended at the assay's limit (the forecaster's own chance of this, stated with the estimate: 50%); at least 1.1-fold (0.04 log units) between middle value and limit.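

In this assay compound 4 gives > 50000 nM, a limit of the assay and not a number. For the compounds shown here, the first reading for tert-butyl in place of thiophen-2-yl on this aromatic carbon is an at least 1.2-fold higher number from compound 2 to compound 4 (0.11 log units; that floor lies within the scatter), so the change has only a floor, with no size yet. Compound 2 remains the only compound with a number, and the series now stands largely at one value: the limit of > 50000 nM in this assay, at which 3 of the 4 values shown sit.

From the compounds shown here alone, the true size of this step stays open. Also open, going by these compounds, is whether an amine, a carboxylic acid or a longer chain on this carbon would give a number in this assay.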